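The source may hold more compounds than are shown below. What is called first, only, known or untested is meant among the compounds shown, and "the series" means these compounds.

Compound 1 `O=C([C@H]1CC2CCC1C2)N1CC(c2nc(-c3ccccc3)no2)C1` joins a bicyclic amide to a phenyl-bearing core. In an assay on HEK293 cells for positive allosteric modulation of metabotropic glutamate receptor 5 (Homo sapiens), read by FLIPR (a lower number here means that less compound is needed, a higher number that more compound is needed for the effect), compound 1 gives 120 nM. Among the three measured compounds this is the only true number. Compound 2 `Cc1ccc(S(=O)(=O)N2CC(c3nc(-c4cccc(Cl)c4)no3)C2)cc1` carries a sulfonamide instead of that amide, and in this assay compound 2 gives > 10000 nM, which is a limit of the assay and not a number. Compound 3 `O=S(=O)(c1ccc(F)cc1)N1CC(c2nc(-c3cccc(Cl)c3)no2)C1` differs from compound 2 by fluoro in place of methyl on an aromatic carbon, and in this assay compound 3 gives > 10000 nM, again a limit. The step that the two limits leave unreadable from compound 2 to compound 3 accordingly has no readable size. Two of the three values rest at the limit of > 10000 nM in this assay, at which 2 of the 3 values shown sit.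

Compound 4 `O=C([C@H]1CC2CCC1C2)N1CC(c2nc(-c3cccc(Cl)c3)no2)C1` keeps the amide of compound 1 and differs from it by chloro in place of hydrogen on an aromatic carbon. Among the measured compounds shown here, no measured step touches this change: the one step available sits between two limits and concerns a different ring. Compounds 2 and 3 do carry 3-chlorophenyl, but they also lack the amide, so their limits reveal nothing about the chloro alone. Without such guidance, the expectation is a step of a 1.1-fold lower number from compound 1 to compound 4 (0.04 log units; within the scatter) that stays within the scatter. Compound 4 is estimated at 110 nM, in the range 40 nM to 350 nM.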

Compound 4, half-maximal effective concentration: 74 nM
Compound 4: middle estimate off by 1.5-fold (0.17 log units), on the high side; the measured number falls inside the stated range.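

Replacing hydrogen with chloro on the phenyl ring of compound 1 gives a 1.6-fold lower number from compound 1 to compound 4 (0.21 log units; within the scatter), so in this assay this change cannot be separated from ordinary repeat-to-repeat variation. Among the compounds shown here, this is the first readable step at this place on the ring, and it shows that, with the bicyclic amide kept, the ring can carry this single chlorine atom without a clear change in the number; compound 4 therefore belongs with compound 1 as a compound with a real reading, and one step on one pair is all that this statement rests on. The values shown offer no measured property that could explain this step, and no reason for it can be given.

Going by these compounds, what a larger or differently built group would do at this same place remains open, for example a methoxy group, a nitrile, an amine or a carboxylic acid. It is also open whether the phenyl to 3-chlorophenyl change would give a similarly small step on a compound with some other group in place of the bicyclic amide, since the sulfonamides shown offer no phenyl and 3-chlorophenyl pair.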